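Bromo for fluoro on the aniline ring

The source may report more compounds than this note shows. Statements on the series, on what has been measured and on what is new or still open speak of the compounds shown alone.

Compound 1 `C=CC(=O)Nc1cccc(NC(=O)CSc2nc(Nc3ccccc3F)c3ccccc3n2)c1` gives 9340 nM in a functional assay on PC-3 cells (Homo sapiens) for inhibition, read by MTT assay, with a stated time of 72 h; on this read-out lower numbers stand for stronger inhibition and higher numbers for weaker inhibition.
Compound 2 `C=CC(=O)Nc1cccc(NC(=O)CSc2nc(Nc3ccccc3Br)c3ccccc3n2)c1` gives 17100 nM in this assay.
Compound 3 `C=CC(=O)Nc1cccc(NC(=O)CSc2nc(Nc3ccc(F)cc3)c3ccccc3n2)c1` gives 8240 nM in this assay.

Among these three numbers compound 3 stands lowest. Its nearest neighbour is compound 1, and the step of a 1.1-fold lower number from compound 1 to compound 3 (0.05 log units; within the scatter) lies within the scatter, so the two cannot be told apart. The step of a 2.1-fold lower number from compound 2 to compound 3 (0.32 log units; beyond the scatter) is the only one that reaches beyond the scatter, and even that is modest.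

Compound 4 `C=CC(=O)Nc1cccc(NC(=O)CSc2nc(Nc3ccc(Br)cc3)c3ccccc3n2)c1` has not yet been measured. It differs from compound 3 by bromo in place of fluoro on an aromatic carbon: the fluoro leaves and a bromo enters, on an aromatic carbon of a six-membered aromatic ring of carbon only, para to a large group. Among the measured compounds shown here, one measured step bears on this change: a 1.8-fold higher number from compound 1 to compound 2 (0.26 log units; within the scatter), the same swap on the same ring, there on 2-fluorophenyl rather than on 4-fluorophenyl. Because that step a 1.8-fold higher number from compound 1 to compound 2 (0.26 log units; within the scatter) stayed within the scatter, no step beyond the scatter is expected here either, although a slight rise in the number is the likelier direction. The step expected is a 1.3-fold higher number from compound 3 to compound 4 (0.13 log units; within the scatter). Compound 4 is therefore estimated at 11000 nM, with a range from 5000 nM to 25000 nM.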

Compound 4, half-maximal inhibitory concentration: 12400 nM
Beside the measured number, compound 4's estimate is 1.1-fold (0.05 log units) below it; the measured number falls inside the stated range.
By their numbers in this assay, from the lowest: compounds 3, 1, 4 and 2 (each within the scatter of the next, the first and the last beyond it).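

The swap of fluoro for bromo can now be read on two aryl groups, and on the 4-fluorophenyl group it gives a 1.5-fold higher number from compound 3 to compound 4 (0.18 log units; within the scatter), so at this place, para to a large group, the change again does not separate the two compounds in this assay. The two readings of this swap also agree with each other, which makes it the one change here seen twice with much the same small size: the same change on two cores in this assay, a 1.8-fold higher number (0.26 log units; within the scatter) from compound 1 to compound 2 and a 1.5-fold higher number (0.18 log units; within the scatter) from compound 3 to compound 4, 1.2-fold (0.09 log units) apart, within the scatter of two such steps

Exchanging the whole aryl group on the nitrogen does no more, with a 1.4-fold lower number from compound 2 to compound 4 (0.14 log units; within the scatter) for 4-bromophenyl in place of 2-bromophenyl and a 1.3-fold higher number from compound 1 to compound 4 (0.12 log units; within the scatter) for 4-bromophenyl in place of 2-fluorophenyl, both steps staying within the scatter.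

Going by these compounds, what remains open is whether a group of another kind on this ring, such as a methoxy group, an amine or a carboxylic acid, would shift the number by more than a swap of one halogen for another does. The compounds shown also leave open whether these small steps would hold on a core carrying a different chain in place of the shared one.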